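From 2-bromophenyl to 4-bromophenyl on the shared core

The source may hold more compounds than are shown below. What is called first, only, known or untested is meant among the compounds shown, and "the series" means these compounds.

Of the compounds shown here, two have values so far. In an ADME assay on Vero cells (Chlorocebus sabaeus) for cytotoxicity, read by MTT assay, with a stated time of 72 h (a higher number here means a weaker inhibitor, a lower number a stronger inhibitor), compound 1 (`O=C(NNC(=O)c1ccc([N+](=O)[O-])cc1)c1ccc(-n2cccc2)cc1`) gives 190000 nM and compound 2 (`O=C(NNC(=O)c1ccccc1Br)c1ccc(-n2cccc2)cc1`) gives 198000 nM as its read-out. These two values lie within the usual scatter of each other, so compound 2 cannot be separated from compound 1 on the numbers available.

Compound 3 (`O=C(NNC(=O)c1ccc(-n2cccc2)cc1)c1ccc(Br)cc1`) has 4-bromophenyl in place of 2-bromophenyl on a carbonyl carbon and keeps the same atoms, joined differently. Among the measured compounds shown here, no measured step covers this change, and the data hold no direct precedent for it.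

The expected step of a 1.0-fold lower number from compound 2 to compound 3 (0.01 log units; within the scatter) in this assay stays within the scatter, with no direction favoured. This expectation rests only on compound 1 at 190000 nM and compound 2 at 198000 nM falling so close together, which is thin support from two compounds. Compound 3 is expected at 195000 nM in this measurement, with an estimated range from 100000 nM to 350000 nM around that middle value.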

Compound 3, half-maximal inhibitory concentration: 186000 nM
The estimate for compound 3 lay 1.0-fold (0.02 log units) above the measured number, and the stated range covers the measured number.
By their numbers in this assay, from the lowest: compounds 3, 1 and 2 (each within the scatter of the next).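

In this assay, among the compounds shown here, 4-bromophenyl in place of 2-bromophenyl on a carbonyl carbon gives a 1.1-fold lower number from compound 2 to compound 3 (0.03 log units; within the scatter) and provides the first direct comparison between compounds that differ in one place. Bromo in place of nitro on an aromatic carbon gives a 1.0-fold lower number from compound 1 to compound 3 (0.01 log units; within the scatter) and adds a second such comparison, this time a change of group rather than of bromine placement. Neither change separates the compounds in this cytotoxicity read-out, and nothing in the data on hand offers an explanation for how closely the three values agree.

Still open, from the compounds shown here alone, is whether any group on this phenyl ring can produce a step beyond the scatter, since compound 1, compound 2 and compound 3 cover only nitro and bromo, and an amine or a carboxylic acid in place of bromo would test that more widely. Also open is whether the flat picture holds when the phenyl ring on the carbonyl carbon gives way to a longer chain, or when the shared core itself changes, as every compound shown keeps that core intact.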